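Methoxy position on the anilide of the shared core

The source may report more compounds than this note shows. Statements on the series, on what has been measured and on what is new or still open speak of the compounds shown alone.

Compound 1 `C/C(=N\OCC(=O)Nc1ccccc1)C1=C(O)c2ccccc2S(=O)(=O)N1C` carries an unsubstituted phenyl on the amide nitrogen of the shared core. In a functional assay on THP-1 cells (Homo sapiens) for inhibition, read by ELISA, with stated times of 2 h and 48 h (on this read-out higher numbers stand for weaker inhibition and lower numbers for stronger inhibition), compound 1 gives only a limit of the assay, > 20000 nM. Compound 2 `COc1cccc(NC(=O)CO/N=C(\C)C2=C(O)c3ccccc3S(=O)(=O)N2C)c1` has a methoxy in place of hydrogen on an aromatic carbon. In this assay compound 2 likewise gives only a limit, > 20000 nM. The step that the two limits leave unreadable from compound 1 to compound 2 therefore cannot be read; both values sit at the limit of > 20000 nM in this assay, at which 2 of the 2 values shown sit, so compound 2 stands at the top of the measured range with no number of its own.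

Compound 3 `COc1ccc(NC(=O)CO/N=C(\C)C2=C(O)c3ccccc3S(=O)(=O)N2C)cc1` differs from compound 2 by 4-methoxyphenyl in place of 3-methoxyphenyl on an amide-type nitrogen. For the measured compounds named here, no measured step moves the methoxy around the ring, and the one step measured, a step that the two limits leave unreadable from compound 1 to compound 2, is itself unreadable and offers no direction; the only evidence is the limit of > 20000 nM in this assay, at which 2 of the 2 values shown sit. The change is expected to give a step that the limit leaves unreadable from compound 2 to compound 3 of no readable size, most likely again ending at the limit. Compound 3 is therefore estimated at 30000 nM, within 10000 nM to 100000 nM.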

Compound 3, half-maximal inhibitory concentration: > 20000 nM
Compound 3: a limit, no number; the forecaster's own chance of this, stated with the estimate: 85%; the middle value does not contradict the limit.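

In this assay, for the compounds shown here, compound 3 gives > 20000 nM, a limit of the assay and not a number, so no step among compound 1, compound 2 and compound 3 can be read. The compounds shown leave open whether any substituent or position on the phenyl on the amide nitrogen gives a readable inhibition: the limit of > 20000 nM in this assay, at which 3 of the 3 values shown sit.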